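Butoxy to Methoxy on a Weakly Active Core

A few compounds are considered here, and "the series" means these few. Any claim that something is new, unique, unknown or untested is made for them only; others in the source may bear on it.

Going by the values given here, compound 1 `CCCCOC1(c2ccc(Br)cc2)SC=C(C)n2c1noc2=O` is the one compound among the three with an actual number in a functional assay on A2780/DX3 cells (Homo sapiens) for antiproliferative activity, read by MTT assay, with a stated time of 3 days; on this read-out lower numbers stand for stronger inhibition and higher numbers for weaker inhibition; in that test compound 1 gives 78000 nM. Compound 2 `COc1ccc(C2(O)SC=C(C)n3c2noc3=O)cc1` reaches only the limit of the assay, > 100000 nM, in this assay. Compound 3 `CCCCCCCCCCCCCCCCCCOC1(c2ccc(Br)cc2)SC=C(C)n2c1noc2=O` likewise stops at the limit, > 100000 nM, in this assay. Two of the three results therefore sit at the limit of > 100000 nM in this assay, at which 2 of the 3 values shown sit, and compound 1 stands alone as a measured value.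

Compound 4 `COC1(c2ccc(Br)cc2)SC=C(C)n2c1noc2=O` has not yet been measured. It differs from compound 1 by hydrogen in place of propyl on a saturated chain carbon bound to an oxygen on a saturated carbon, so that butoxy becomes methoxy. Among the compounds with values here, no pair of measured compounds differs in just one place, so no step of this kind has been seen. Because compound 1 gives 78000 nM in this assay, the step from compound 1 to compound 4 is expected to be a 1.0-fold higher number from compound 1 to compound 4 (0.01 log units; within the scatter), that is, nothing beyond the usual scatter. Compound 4 is expected to give 80000 nM, in a range from 30000 nM to 200000 nM.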

Compound 4, half-maximal inhibitory concentration: > 100000 nM
Compound 4: no number, only a limit (the forecaster's own chance of this, stated with the estimate: 40%); middle value at least 1.2-fold (0.09 log units) away from the limit.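

In this assay compound 4 gives > 100000 nM, which is a limit of the assay and not a number. Going by these compounds, replacing propyl with hydrogen on the saturated chain carbon, so that butoxy becomes methoxy, gives an at least 1.2-fold higher number from compound 1 to compound 4 (0.10 log units; that floor lies within the scatter), so this first single-place comparison on the shared core shows no gain in activity from the shorter group, while the true size of the change stays unknown. The comparison also leaves little room to read finer differences, as most results now stop at the same ceiling: the limit of > 100000 nM in this assay, at which 3 of the 4 values shown sit.

On these data alone, it remains open whether an amine or a carboxylic acid in place of propyl on that chain carbon would give a measurable number in this assay. The compounds shown also do not tell whether any group at this position can bring a clear gain in activity.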